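From a bare amino group to 4-methoxyphenyl on compound 1

The compounds below may be only part of what the source reports. "The series", "measured", "known", "first", "only" and "open" are said of these compounds alone.

Measured so far in this study:
compound 1, `CCN(CC)CN1C(=O)/C(=N/NC(N)=S)c2ccccc21` — 164000 nM
compound 2, `CCN(CC)CN1C(=O)/C(=N/NC(=S)Nc2ccc(Cl)cc2)c2cc(Cl)ccc21` — > 125000 nM (a limit of the assay, not a number)
compound 3, `CCN(CC)CN1C(=O)/C(=N/NC(=S)Nc2ccccc2)c2ccccc21` — 11000 nM

All three share one core and differ in what sits on an amide-type nitrogen whose other neighbour is a thiocarbonyl carbon. In a functional assay on CCRF-CEM cells (Homo sapiens) for inhibition, read by cell counting, with a stated time of 72 h (on this read-out higher numbers stand for weaker inhibition and lower numbers for stronger inhibition), compound 1 gives 164000 nM, the highest of the two plain numbers shown; its nearest neighbour is compound 3, which gives 11000 nM. For compound 2 the assay reports only a limit, > 125000 nM, and that says no more than that it is one (the limit of > 125000 nM in this assay, at which 1 of the 3 values shown sits).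

Compound 4, `CCN(CC)CN1C(=O)/C(=N/NC(=S)Nc2ccc(OC)cc2)c2ccccc21`, has not yet been measured. It differs from compound 1 by 4-methoxyphenyl in place of hydrogen on an amide-type nitrogen. For the measured compounds named here, the only measured step that bears directly on this change is the one in which a plain phenyl enters at the same place: a 15-fold lower number from compound 1 to compound 3 (1.17 log units; beyond the scatter). Since 4-methoxyphenyl carries that same phenyl ring, a step of comparable size and the same downward direction is expected for compound 4, tempered somewhat, since compound 2, which also carries a substituted phenyl there, did not yield a number. Compound 4 is therefore estimated at 20000 nM, with a likely range of 5000 nM to 80000 nM. That estimate means an expected step of an 8.2-fold lower number from compound 1 to compound 4 (0.91 log units; beyond the scatter).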

Compound 4, half-maximal inhibitory concentration: 1900 nM
Estimate against measurement, compound 4: 11-fold (1.02 log units) above; measured number below the stated range.
By their numbers in this assay, from the lowest: compound 4; then compound 3; then compound 1.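

The result in this assay shows that the gain at this amide-type nitrogen does not stop at a plain phenyl: the full change to 4-methoxyphenyl gives an 86-fold lower number from compound 1 to compound 4 (1.94 log units; beyond the scatter) and goes clearly further than phenyl alone did. What is new is that the ring entering here can itself be tuned, as methoxy in place of hydrogen on an aromatic carbon of that ring gives a 5.8-fold lower number from compound 3 to compound 4 (0.76 log units; beyond the scatter) on top of the phenyl step, so a small addition to this ring still moves the number by more than the usual scatter. Nothing measured in this set explains why this addition lowers the number, and the size of the step is all that can be stated.

From the compounds shown here alone, whether this gain is particular to methoxy stays open, and so does whether another group on the same ring, such as methyl, hydroxyl or a carboxylic acid, would do as well, would do better or would lose the gain. Compound 2 differs from compound 3 in more than one place and offers only a limit rather than a number, so it cannot settle this: the limit of > 125000 nM in this assay, at which 1 of the 4 values shown sits.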